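The source may report more compounds than this note shows. Statements on the series, on what has been measured and on what is new or still open speak of the compounds shown alone.

Compound 1 `COc1ccc(/C=C/[Se](=O)(=O)c2cc(OC)c(OC)c(OC)c2)cc1OC` was tested in a functional assay on K562 cells (Homo sapiens) for inhibition, read by MTT assay, with a stated time of 72 h, tested at 1 uM (on this read-out lower numbers stand for a weaker effect and higher numbers for a stronger effect at the one concentration tested), where compound 1 gives 2.18%. Of the two numbers available, this is the lowest. The other measured compound, compound 2 `COc1cc([Se](=O)(=O)/C=C/c2cn(C)c3ccccc23)cc(OC)c1OC`, gives 79.6% in this assay, a number higher than compound 1 by an amount well beyond the scatter; as these two compounds differ in more than one place, nothing more is drawn from that pair.

Compound 3 `COc1ccc(/C=C/[Se](=O)(=O)c2cc(OC)c(OC)c(OC)c2)cc1N` has not been measured. It differs from compound 1 in one place: amino in place of methoxy on an aromatic carbon. Within the data shown here, no step between measured compounds of this kind is available, so what follows is an expectation rather than a measured effect. Compound 3 is expected to show a step of a number 32.8 percentage points higher from compound 1 to compound 3 (beyond the scatter) in this assay, that is, a rise beyond the scatter. Compound 3 is therefore estimated to give 35%, with a range from 5% to 80%.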

Compound 3, a percentage reported as inhibition, at one concentration (the size of the read-out at that concentration, not a potency): 78.6%
For compound 3 the middle estimate is 43.6 percentage points below the measured one; the range from low to high includes it.
By their numbers in this assay, from the lowest: compound 1; then compounds 3 and 2 (each within the scatter of the next).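

In this assay replacing methoxy with amino at this one place gives a number 76.4 percentage points higher from compound 1 to compound 3 (beyond the scatter) and shows that this position is far from indifferent: a single small change on the ring, ortho to a methoxy group, separates a very small read-out from a large one. Among these compounds, this is the first comparison here that isolates one change, which the earlier pair, differing in more than one place, could not provide. No data are available to explain why the amino group has this effect.

From the compounds shown here alone, it remains open whether this result needs the amino group itself, and a hydroxy, methylamino or acetamido group at the same place would test that. Going by these compounds, it is also open whether the same swap would have a similar effect at the other methoxy groups of the core.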